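The source may report more compounds than this note shows. Statements on the series, on what has been measured and on what is new or still open speak of the compounds shown alone.

Measured so far:
compound 1, `Cc1cccc(NNS(=O)(=O)c2ccc(C(=O)NCC(=O)O)cc2)c1` — 80 nM
compound 2, `CC(=O)Nc1ccc(S(=O)(=O)NNc2ccccc2)cc1` — 71 nM

In an assay for inhibition of Indoleamine 2,3-dioxygenase 1 (Homo sapiens), read by spectrophotometry, with stated times of 1 h and 4 h (a higher number here means a weaker inhibitor, a lower number a stronger inhibitor), compound 2 gives 71 nM, the lowest of the two numbers, although compound 1 sits within the scatter of it, so the two cannot be ranked. Compound 3, `CC(=O)Nc1ccc(S(=O)(=O)NNc2ccc(C#N)cc2)cc1`, has not been measured. It differs from compound 2 by cyano in place of hydrogen on an aromatic carbon. Within the data shown here, no step between measured compounds tells how such a change acts here, so the expectation rests on compound 2 alone, with a step that could fall either way and is estimated as a 1.2-fold lower number from compound 2 to compound 3 (0.07 log units; within the scatter). Compound 3 is expected to give about 60 nM, within a range from 20 nM to 200 nM.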

Compound 3, half-maximal inhibitory concentration: 5670 nM
Beside the measured number, compound 3's estimate is 95-fold (1.98 log units) below it; the whole stated range lies below it.
By their numbers in this assay, from the lowest: compounds 2 and 1 (each within the scatter of the next); then compound 3.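

In this assay, the position para to a large group on the six-membered aromatic ring turns out not to be free for substitution: cyano in place of hydrogen there gives an 80-fold higher number from compound 2 to compound 3 (1.90 log units; beyond the scatter). Compound 1 and compound 2 differ in more than one place, so they offered no view of this single change.

Going by these compounds, whether any group at this position costs as much, or cyano alone does, stays open; fluorine, a methoxy group or an amine there would help separate the two. Nothing measured here accounts for the size of this step.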